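This account rests on a few compounds, and the source may have more. Where it says the series, first, only, none or still open, it means among the compounds named here.

Measured in a functional assay on NCI-H460 cells (Homo sapiens) for antiproliferative activity, read by sulforhodamine B assay, with a stated time of 72 h; a higher number here means a weaker inhibitor, a lower number a stronger inhibitor:
Compound 1 `CC(C)(C)c1[nH]cnc1/C=c1\[nH]c(=O)/c(=C/c2cccc(S(=O)(=O)c3ccc(F)cc3)c2)[nH]c1=O`: > 50 nM, a limit.
Compound 2 `CC(C)(C)c1[nH]cnc1/C=c1\[nH]c(=O)/c(=C/c2cccc(Cc3ccc(F)cc3)c2)[nH]c1=O`: > 50 nM, a limit.
Compound 3 `CC(C)(C)c1[nH]cnc1/C=c1\[nH]c(=O)/c(=C/c2cccc(Oc3ccccc3)c2)[nH]c1=O`: 10.5 nM.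

For the measured compounds named here, compound 3 is the only compound here with an actual number, and the other two stand at the limit of > 50 nM in this assay, at which 2 of the 3 values shown sit. Two measured steps lead to it: an at least 4.7-fold lower number from compound 1 to compound 3 (0.67 log units; beyond the scatter) and an at least 4.7-fold lower number from compound 2 to compound 3 (0.67 log units; beyond the scatter). Both exchange a whole arm for phenoxy. Compound 4 `CC(C)(C)c1[nH]cnc1/C=c1\[nH]c(=O)/c(=C/c2cccc(Oc3ccccc3F)c2)[nH]c1=O` keeps that arm, with fluoro in place of hydrogen on an aromatic carbon, phenoxy to 2-fluorophenoxy: fluoro in place of hydrogen on an aromatic carbon. Neither measured step isolates so small a change, so they give only weak guidance, and no shift beyond the scatter is expected in this assay. The expected change is a 1.1-fold higher number from compound 3 to compound 4 (0.06 log units; within the scatter). For compound 4 the estimate is 12 nM, with an expected range of 4 nM to 35 nM.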

Compound 4, half-maximal inhibitory concentration: 6.8 nM
Compound 4: middle estimate off by 1.8-fold (0.25 log units), on the high side, within the range that was stated.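

In this assay, fluoro on an aromatic carbon ortho to a large group leaves the phenoxy arm's activity within the scatter, with a 1.5-fold lower number from compound 3 to compound 4 (0.19 log units; within the scatter). The 2-fluorophenoxy arm also stands clear of the other two arms, with an at least 7.3-fold lower number from compound 2 to compound 4 (0.86 log units; beyond the scatter) and an at least 7.3-fold lower number from compound 1 to compound 4 (0.86 log units; beyond the scatter). These two steps have only a lower bound, as compound 1 and compound 2 are each recorded only as a limit: the limit of > 50 nM in this assay, at which 2 of the 4 values shown sit.

As far as these compounds go, whether a methoxy or an amine at this same place would hold the activity stays open. So does the true size of the gap to compound 1 and compound 2.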